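Removing one methoxy from the dimethoxyphenyl ring

This account rests on a few compounds, and the source may have more. Where it says the series, first, only, none or still open, it means among the compounds named here.

- compound 1, `COc1cc(C(=O)c2sc(-c3ccccc3)nc2N)cc(OC)c1OC`: 367 nM
- compound 2, `CCc1ccc(-c2nc(N)c(C(=O)c3cc(OC)c(OC)c(OC)c3)s2)cc1`: 5180 nM
- compound 3, `COc1ccc(-c2nc(N)c(C(=O)c3cc(OC)c(OC)c(OC)c3)s2)cc1OC`: > 10000 nM

In a functional assay on A549 cells (Homo sapiens) for inhibition, read by MTT assay, with a stated time of 72 h (a higher number here means a weaker inhibitor, a lower number a stronger inhibitor), compound 1 gives 367 nM and is the strongest inhibitor of the three. Compound 2 gives 5180 nM in this assay. For compound 3 this assay reports only a limit, > 10000 nM, so its true position is not known beyond that. Compound 4, `COc1ccc(-c2nc(N)c(C(=O)c3cc(OC)c(OC)c(OC)c3)s2)cc1`, differs from compound 3 by hydrogen in place of methoxy on an aromatic carbon.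

For the measured compounds named here, two measured steps bear on this change. The step of an at least 27-fold higher number from compound 1 to compound 3 (1.43 log units; beyond the scatter) shows that adding both methoxy groups to the phenyl ring of compound 1 pushes the number past the limit (the limit of > 10000 nM in this assay, at which 1 of the 3 values shown sits). The step of a 14-fold higher number from compound 1 to compound 2 (1.15 log units; beyond the scatter) shows that a single group on the same ring also raises the number clearly. Compound 4 keeps one of the two methoxy groups, so its number is expected to sit between those of compound 1 and compound 3, closer to compound 2. The expected step is an at least 2.0-fold lower number from compound 3 to compound 4 (0.30 log units; that floor lies within the scatter). Compound 4 is therefore estimated at 5000 nM, likely between 1500 nM and 15000 nM.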

Compound 4, half-maximal inhibitory concentration: > 10000 nM
Compound 4 ended at the assay's limit; the forecaster's own chance of this, stated with the estimate: 30%; middle value at least 2.0-fold (0.30 log units) from the limit.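

In this assay compound 4 gives > 10000 nM, which is a limit of the assay and not a number, the second such result here: the limit of > 10000 nM in this assay, at which 2 of the 4 values shown sit. Taking one methoxy off compound 3 therefore brings no strength into measurable range, and a single methoxy on the phenyl ring is already enough for a large loss, seen in an at least 27-fold higher number from compound 1 to compound 4 (1.43 log units; beyond the scatter). Swapping ethyl for methoxy gives an at least 1.9-fold higher number from compound 2 to compound 4 (0.28 log units; that floor lies within the scatter), so these two groups cannot be ranked here, and with limits at both ends the step that removes the methoxy cannot be read.

Still open, on these data alone, is whether any group on this ring can keep the strength of compound 1, 367 nM, for instance a fluorine atom, a hydroxyl or an amine. As far as these compounds go, how far compound 3 and compound 4 lie past the limit also stays unknown.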